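A few compounds are considered here, and "the series" means these few. Any claim that something is new, unique, unknown or untested is made for them only; others in the source may bear on it.

Compound 3 `CSc1cnc2ccccc2c1SCC#CCO`: 2.3 ug/mL
Compound 1 `OCC#CCSc1cnc2ccccc2c1SCC#CCCl`: 3.3 ug/mL
Compound 2 `OCC#CCSc1cnc2ccccc2c1Cl`: 4.1 ug/mL

In a functional assay on CCRF-CEM cells (Homo sapiens) for antiproliferative activity, with a stated time of 72 h (a lower number here means a stronger inhibitor, a higher number a weaker inhibitor), compound 3 gives the lowest of the three numbers, yet its steps to compound 1 and to compound 2 both lie within the scatter, so no order among the three can be claimed. Compound 4 `CSc1cnc2ccccc2c1SCC#CCOC(=O)c1ccccc1` differs from compound 3 by benzoyl in place of hydrogen on an oxygen on a saturated carbon. Among the compounds with values here, the one measured step, a 1.2-fold higher number from compound 1 to compound 2 (0.09 log units; within the scatter), concerns a substituent on an aromatic carbon of the shared core, not the oxygen on a saturated carbon, so it does not bear directly on this change; no measured pair shows the effect of a benzoyl. All three numbers sit close together. Compound 4 is therefore expected to stay near compound 3, with an estimated step of a 1.3-fold higher number from compound 3 to compound 4 (0.12 log units; within the scatter). The estimate for compound 4 is 3 ug/mL, range 1.2 ug/mL to 7.5 ug/mL.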

Compound 4, concentration for 50% inhibition: 22.2 ug/mL
Estimate against measurement, compound 4: 7.4-fold (0.87 log units) below; the whole stated range lies below it.
By their numbers in this assay, from the lowest: compounds 3, 1 and 2 (each within the scatter of the next); then compound 4.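

In this assay, within the data shown here, benzoyl in place of hydrogen on the oxygen on a saturated carbon gives a 9.7-fold higher number from compound 3 to compound 4 (0.98 log units; beyond the scatter), the only step that lies beyond the scatter. Among these compounds, this oxygen is therefore a place where a change can shift the number, which the earlier compounds, all close together, did not reveal. No available evidence accounts for the step. As far as these compounds go, whether the shift follows the aromatic ring or the carbonyl of the benzoyl remains open. An acetyl or a methyl on the same oxygen would help separate the two.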